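Diethylamino in place of hydrogen on compound 1

The compounds below may be only part of what the source reports. "The series", "measured", "known", "first", "only" and "open" are said of these compounds alone.

In a functional assay on MCF7 cells (Homo sapiens) for cytotoxicity, read by MTT assay, with a stated time of 72 h (a higher number here means a weaker inhibitor, a lower number a stronger inhibitor), compound 1 (`O=c1ccc2nc(-c3ccccc3)nn(-c3ccccc3)c-2c1`) gives 810 nM and compound 2 (`Nc1cc2nc(-c3ccccc3)nn(-c3ccccc3)c-2cc1=O`) gives 950 nM. Going by the values given here, these two values lie within the scatter of each other, so compound 1 does not stand apart from compound 2 on the numbers so far.

Compound 3 (`CCN(CC)c1cc2nc(-c3ccccc3)nn(-c3ccccc3)c-2cc1=O`) has not yet been measured. Its difference from compound 1 is diethylamino in place of hydrogen on an aromatic carbon, with diethylamino in place of hydrogen on an aromatic carbon.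

Among the compounds with values here, the one measured step that bears on this change is a 1.2-fold higher number from compound 1 to compound 2 (0.07 log units; within the scatter), for amino in place of hydrogen on an aromatic carbon. On the basis of that step, no change beyond the scatter is expected in this assay. Within the data shown here, the guide is thin, however: no measured compound carries diethylamino, so the expected range is kept wide on both sides.

The expected step is a 1.5-fold higher number from compound 1 to compound 3 (0.17 log units; within the scatter).

For compound 3 the estimated value is 1200 nM, with an expected range of 400 nM to 3500 nM.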

Compound 3, half-maximal inhibitory concentration: > 5000 nM
Compound 3: a limit, no number (the forecaster's own chance of this, stated with the estimate: 5%); at least 4.1-fold (0.61 log units) between middle value and limit.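

In this assay compound 3 gives > 5000 nM, which is a limit of the assay and not a number. The aromatic carbon that carries the new group did not respond to amino, with a 1.2-fold higher number from compound 1 to compound 2 (0.07 log units; within the scatter), but it does respond to diethylamino, with an at least 6.1-fold higher number from compound 1 to compound 3 (0.79 log units; beyond the scatter), so this position is not indifferent to what is placed on it. Exchanging amino for diethylamino at the same carbon gives an at least 5.2-fold higher number from compound 2 to compound 3 (0.72 log units; beyond the scatter), which shows that a nitrogen on this carbon does not by itself set the outcome in this pair, and that the change from amino to diethylamino carries the step.

How far the step extends stays open, and the compounds shown fix only its lower bound: the limit of > 5000 nM in this assay, at which 1 of the 3 values shown sits. Also open, from the compounds shown here alone, is whether methylamino, ethylamino or a cyclic amine such as morpholine at this carbon would stay with compound 1 and compound 2 or move with compound 3, and so whether the step follows the size of the group or something else about diethylamino.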